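The source may hold more compounds than are shown below. What is called first, only, known or untested is meant among the compounds shown, and "the series" means these compounds.

Measured compounds:
- compound 1, `O=C(/C=C/c1ccc(OCc2cn(Cc3ccccc3Br)nn2)cc1)c1ccc(Br)cc1`: 34%
- compound 2, `O=C(/C=C/c1ccc(OCc2cn(Cc3ccccc3)nn2)cc1)c1ccc([N+](=O)[O-])cc1`: "not active" (no number reported)

The account follows the move from compound 2 to compound 3. In a functional assay on HepG2 cells (Homo sapiens) for inhibition, read by MTT assay, with a stated time of 48 h, tested at 10 uM (on this read-out higher numbers stand for more inhibition of growth at the one concentration tested and lower numbers for less inhibition of growth), compound 1 gives 34%. In this assay compound 2 is reported as "not active" (no number reported), so no single number places it on the scale, and nothing can be said of a gap between compound 1 and compound 2 beyond that one has a number and the other has none.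

Compound 3, `O=C(/C=C/c1ccc(OCc2cn(Cc3ccccc3Br)nn2)cc1)c1ccc([N+](=O)[O-])cc1`, has not been measured. It differs from compound 2 by bromo in place of hydrogen on an aromatic carbon. For the measured compounds named here, no step between measured compounds covers this change, so the expected size rests on the two values shown only: compound 1, which carries the same bromobenzyl group, gives 34%, while compound 2 gives none. A step upward from compound 2 of modest size is expected, possibly within the scatter. Compound 3 is estimated at 20%, with a range from 0% to 45%.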

Compound 3, percent growth inhibition at one concentration: 32%
Estimate against measurement, compound 3: 12 percentage points below; the measured number falls inside the stated range.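

In this assay compound 3 has a number where compound 2, with hydrogen in place of the bromo, is reported only as "not active", so the change from benzyl to 2-bromobenzyl goes with a measurable reading, though the size of that change cannot be read. Nitro in place of bromo on an aromatic carbon gives a number 2 percentage points lower from compound 1 to compound 3 (within the scatter), so with the 2-bromobenzyl group held, these two groups cannot be told apart on this read-out. Nothing measured here accounts for the link between the bromo and a numerical reading.

The compounds shown leave open whether chloro, methyl or an amine on the same aromatic carbon would also go with a numerical reading. They also leave open whether the bromo on the benzyl group would do so with hydrogen in place of the nitro or bromo on the other end of the molecule.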